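Amide nitrogen substituents: isobutylcarbamoyl to carbamoyl

This account rests on a few compounds, and the source may have more. Where it says the series, first, only, none or still open, it means among the compounds named here.

Measured in a functional assay on MCF7 cells (Homo sapiens) for antiproliferative activity, read by CCK-8 assay, with a stated time of 72 h (a lower number here means a stronger inhibitor of growth, a higher number a weaker inhibitor of growth), so far

- compound 1 `CCC1C(=O)N(C)c2cnc(-n3ccc4cc(C(=O)NC(C)C)ccc43)nc2N1c1ccn(C)n1` gives 8420 nM
- compound 2 `CCC1C(=O)N(C)c2cnc(-n3ccc4cc(C(=O)NC)ccc43)nc2N1c1ccn(C)n1` gives 35400 nM
- compound 3 `CCC1C(=O)N(C)c2cnc(-n3ccc4cc(C(=O)NCC(C)C)ccc43)nc2N1c1ccn(C)n1` gives 4810 nM

Compound 3 gives 4810 nM and sits level with compound 1 at the low end of these numbers. The step of a 1.8-fold lower number from compound 1 to compound 3 (0.24 log units; within the scatter) does not separate the two. Compound 2 stands apart, with the step of a 7.4-fold lower number from compound 2 to compound 3 (0.87 log units; beyond the scatter) on the record.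

Compound 4 `CCC1C(=O)N(C)c2cnc(-n3ccc4cc(C(N)=O)ccc43)nc2N1c1ccn(C)n1` carries hydrogen in place of isobutyl on an amide-type nitrogen and so turns isobutylcarbamoyl into carbamoyl. Among the measured compounds shown here, no measured compound has hydrogen at this place, so any figure is an extrapolation. For the measured compounds named here, two steps bear on it. The step of a 4.2-fold higher number from compound 1 to compound 2 (0.62 log units; beyond the scatter) and the step of a 7.4-fold lower number from compound 2 to compound 3 (0.87 log units; beyond the scatter) both leave the methyl amide, compound 2, with the highest number of the three. Isopropyl and isobutyl are not resolved from each other, so the trend rests on compound 2 alone. Removing the whole isobutyl is therefore expected to give a change at least comparable to that seen for compound 2 at 35400 nM in this assay and to move towards a higher number. The estimated step is an 8.3-fold higher number from compound 3 to compound 4 (0.92 log units; beyond the scatter) and it is expected to lie beyond the scatter. Compound 4 is expected at 40000 nM with an estimated range from 15000 nM to 100000 nM.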

Compound 4, concentration for 50% growth inhibition: "not active" (no number reported)
Nothing numeric was reported for compound 4, so the estimate cannot be set against anything.
By their numbers in this assay, from the lowest: compounds 3 and 1 (each within the scatter of the next); then compound 2.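

In this assay, among the compounds shown here, compound 4 is recorded only as "not active", without a number, so no step from compound 1, compound 2 or compound 3 to compound 4 can be read. No available evidence bears on this result.

The compounds shown leave open where carbamoyl would fall numerically relative to the methyl amide, compound 2, at 35400 nM in this series.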